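The source may report more compounds than this note shows. Statements on the series, on what has been measured and on what is new or still open speak of the compounds shown alone.

Measured compounds:
- compound 1, `CC(C)N1CCN(S(=O)(=O)CCCN2CCC(CNC(=O)c3cccc4c3OCCO4)CC2)CC1`: 0.0316 nM
- compound 2, `CS(=O)(=O)N1CCN(S(=O)(=O)CCCN2CCC(CNC(=O)c3cccc4c3OCCO4)CC2)CC1`: 0.316 nM
- compound 3, `O=C(NCC1CCN(CCCS(=O)(=O)N2CCOCC2)CC1)c1cccc2c1OCCO2`: 0.398 nM

In an assay on isolated protein for inhibition of 5-hydroxytryptamine receptor 4 (Homo sapiens) (a higher number here means a weaker inhibitor, a lower number a stronger inhibitor), compound 3 gives the highest number of the three, although the step of a 1.3-fold higher number from compound 2 to compound 3 (0.10 log units; within the scatter) is within the scatter, while the step of a 13-fold higher number from compound 1 to compound 3 (1.10 log units; beyond the scatter) is beyond it. Compound 4, `CC(C)S(=O)(=O)N1CCN(S(=O)(=O)CCCN2CCC(CNC(=O)c3cccc4c3OCCO4)CC2)CC1`, has not yet been measured. It differs from compound 3 in one place: 4-(isopropylsulfonyl)piperazin-1-yl in place of morpholin-4-yl on a sulfonyl sulfur.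

Within the data shown here, two measured steps bear on this change. Replacing the morpholine of compound 3 with a piperazine carrying a methylsulfonyl group gives compound 2, and that step, a 1.3-fold higher number from compound 2 to compound 3 (0.10 log units; within the scatter) read backwards, is within the scatter. A piperazine carrying a plain isopropyl group instead, as in compound 1, gives a much lower number, a 13-fold higher number from compound 1 to compound 3 (1.10 log units; beyond the scatter), but the step of a 10-fold higher number from compound 1 to compound 2 (1.00 log units; beyond the scatter) shows that a sulfonyl on that nitrogen loses most of this gain. Compound 4 carries a sulfonyl on that nitrogen, so it is expected to sit close to compound 2 and compound 3, with a step of a 1.3-fold lower number from compound 3 to compound 4 (0.12 log units; within the scatter) that stays within the scatter.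

Compound 4 is therefore estimated at 0.3 nM in this assay, in a range from 0.08 nM to 1.2 nM.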

Compound 4, inhibition constant: 0.126 nM
Estimate against measurement, compound 4: 2.4-fold (0.38 log units) above, within the range that was stated.
By their numbers in this assay, from the lowest: compound 1; then compound 4; then compounds 2 and 3 (each within the scatter of the next).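

In this assay, placing a sulfonyl on the piperazine nitrogen does not fix the result, since what that sulfonyl carries also counts: isopropyl in place of methyl gives a 2.5-fold lower number from compound 2 to compound 4 (0.40 log units; beyond the scatter) and this step lies beyond the scatter. The sulfonyl-bearing piperazine can therefore separate from morpholin-4-yl on the sulfonyl sulfur, as a 3.2-fold lower number from compound 3 to compound 4 (0.50 log units; beyond the scatter) shows, something the methylsulfonyl group did not do. Inserting the sulfonyl while keeping the isopropyl still costs binding strength, with a 4.0-fold higher number from compound 1 to compound 4 (0.60 log units; beyond the scatter) as the measured loss, so the piperazine with a plain isopropyl keeps the lowest number of the four.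

Nothing shown gives a reason for these differences. As far as these compounds go, whether a cyclopropyl or phenyl on that sulfonyl, or an acetyl on the same nitrogen, would lower the number further remains open.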